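Notes on the benzoyloxy analogue in the oxazolidinone series

The source may hold more compounds than are shown below. What is called first, only, known or untested is meant among the compounds shown, and "the series" means these compounds.

Compound 3 `O=C1CNC(=O)N1C[C@H]1CN(c2ccc(-n3cc(-c4ccccn4)cn3)c(F)c2)C(=O)O1` carries a 2,5-dioxoimidazolidin-1-yl group on a saturated chain carbon bound to a saturated ring carbon. In an ADME assay on HEK293-A cells (Homo sapiens) for cytotoxicity, read by MTT assay, with a stated time of 48 h (on this read-out higher numbers stand for weaker inhibition and lower numbers for stronger inhibition), compound 3 reaches only the limit > 400 ug/mL. Compound 1 `CN(CCC#N)C[C@H]1CN(c2ccc(-n3cc(-c4ccccn4)cn3)c(F)c2)C(=O)O1` likewise gives only the limit > 400 ug/mL in this assay. Compound 2 `CCN1CCN(C[C@H]2CN(c3ccc(-n4cc(-c5ccccn5)cn4)c(F)c3)C(=O)O2)CC1` gives 99 ug/mL in this assay, and the step of an at least 4.0-fold higher number from compound 2 to compound 3 (0.60 log units; beyond the scatter) is the one readable movement here; the step that the two limits leave unreadable from compound 1 to compound 3 cannot be sized, since two of the three values sit at the limit of > 400 ug/mL in this assay, at which 2 of the 3 values shown sit.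

Compound 4 `O=C(OC[C@H]1CN(c2ccc(-n3cc(-c4ccccn4)cn3)c(F)c2)C(=O)O1)c1ccccc1` is the unmeasured analogue, differing as benzoyloxy in place of 2,5-dioxoimidazolidin-1-yl on a saturated chain carbon bound to a saturated ring carbon. Within the data shown here, no measured step introduces a benzoyloxy group, so the only guidance is that both neutral replacements at this position, in compound 1 and compound 3, sat at the limit, while the only number below it came with compound 2 and its step of an at least 4.0-fold lower number from compound 1 to compound 2 (0.60 log units; beyond the scatter). For compound 4 the number in this assay is therefore expected near the limit as well, with the step of an at least 1.1-fold lower number from compound 3 to compound 4 (0.05 log units; that floor lies within the scatter) expected to stay within the scatter. The estimate for compound 4 is 350 ug/mL, ranging from 120 ug/mL to 400 ug/mL.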

Compound 4, half-maximal inhibitory concentration: > 400 ug/mL
Compound 4 gave a limit, no number; the forecaster's own chance of this, stated with the estimate: 60%; middle value at least 1.1-fold (0.05 log units) away from the limit.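

In this assay compound 4 gives > 400 ug/mL as a limit and not a number. Benzoyloxy, with its six-membered aromatic ring of carbon only and no hydrogen-bond donor, therefore joins (2-cyanoethyl)(methyl)amino and 2,5-dioxoimidazolidin-1-yl at this place, while an at least 4.0-fold higher number from compound 2 to compound 4 (0.60 log units; beyond the scatter) adds a second readable movement away from 4-ethylpiperazin-1-yl; the steps among compound 1, compound 3 and compound 4 cannot be read. Compound 2 thus remains the only compound here with a measured number, and the other values collect at one point: the limit of > 400 ug/mL in this assay, at which 3 of the 4 values shown sit.

As far as these compounds go, how far compound 1, compound 3 and compound 4 lie from one another stays open. Also open, from the compounds shown here alone, is whether the lower number of compound 2 follows the whole 4-ethylpiperazin-1-yl group, which a morpholin-4-yl group, a primary amine or a carboxylic acid at this place would help to test.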